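Quinazolinone series: ortho substituent swap on the aryl ring

This account rests on a few compounds, and the source may have more. Where it says the series, first, only, none or still open, it means among the compounds named here.

Measured so far:
compound 1, `Cc1ccc2c(=O)[nH]c(-c3ccccc3C)nc2c1`: 100%
compound 2, `Cc1cccc(-c2nc3ccc(C)cc3c(=O)[nH]2)c1`: 75.7%

In an assay on isolated protein for inhibition of DNA topoisomerase 1 (Homo sapiens), with a stated time of 30 min, tested at 100 uM (a lower number here means a weaker effect, a higher number a stronger effect of the compound at the concentration tested), compound 1 gives 100%, the highest of the two numbers. Compound 2, `Cc1cccc(-c2nc3ccc(C)cc3c(=O)[nH]2)c1`, gives 75.7%, which lies beyond the scatter below compound 1, so compound 1 stands alone at the top of this small set.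

Compound 3, `Cc1ccc2c(=O)[nH]c(-c3ccccc3OC(F)(F)F)nc2c1`, is not yet measured. It differs from compound 1 as follows: trifluoromethoxy in place of methyl on an aromatic carbon. The change sits on an aromatic carbon of a six-membered aromatic ring of carbon only, ortho to a large group. Within the data shown here, no measured pair shows this change, so the size of the step in this assay is unknown; a small loss, or none beyond the scatter, is the expectation, given that compound 1 already sits at 100% and cannot rise further. Compound 3 is expected to give 85%, between 55% and 100%, which means an estimated step of a number 15 percentage points lower from compound 1 to compound 3 (beyond the scatter).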

Compound 3, a percentage reported as inhibition, at one concentration (the size of the read-out at that concentration, not a potency): 100%
Estimate against measurement, compound 3: 15 percentage points below; low and high end bracket the measured number.
By their numbers in this assay, from the lowest: compound 2; then compounds 1 and 3 (each within the scatter of the next).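

In this assay, placing trifluoromethoxy in place of methyl gives no change at the digits printed from compound 1 to compound 3 (within the scatter), so this position, ortho to a large group, accepts a group of 5 heavy atoms, including a hydrogen-bond acceptor, without a loss in the read-out. Compound 1 and compound 3 therefore stand together at the top of the set, and a read-out at one concentration gives no order between them. Nothing on hand explains why the position tolerates this change.

The compounds shown leave open whether the effect survives a carboxylic acid, an amine or a longer chain such as n-butyl at this position. They also leave open whether compound 1 and compound 3 would separate into a stronger and a weaker effect at other concentrations.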